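Aryl hydrazone exchange in the adenosine receptor series

The compounds below may be only part of what the source reports. "The series", "measured", "known", "first", "only" and "open" are said of these compounds alone.

Compound 1, `Nc1nc(N/N=C/c2ccc[nH]2)nc2c1ncn2[C@@H]1O[C@H](CO)[C@@H](O)[C@H]1O`, gives 8 nM in an assay on CHO-K1 cells for displacement of a labelled ligand from adenosine receptor A1 (Homo sapiens), read by scintillation counting, with a stated time of 60 min; a lower number here means a stronger inhibitor, a higher number a weaker inhibitor. Compound 2, `Nc1nc(N/N=C/c2ccc(Cl)c(C(F)(F)F)c2)nc2c1ncn2[C@@H]1O[C@H](CO)[C@@H](O)[C@H]1O`, reports only a limit in this assay, > 10000 nM. The step of an at least 1200-fold higher number from compound 1 to compound 2 (3.09 log units; beyond the scatter) is thus known only as a minimum, resting on (the limit of > 10000 nM in this assay, at which 1 of the 2 values shown sits). Compound 3, `Nc1nc(N/N=C/c2ccc(-n3ccnc3)cc2)nc2c1ncn2[C@@H]1O[C@H](CO)[C@@H](O)[C@H]1O`, carries 4-(1H-imidazol-1-yl)phenyl in place of 4-chloro-3-(trifluoromethyl)phenyl on a carbon with a double bond to nitrogen. Among the measured compounds shown here, the one measured step bears on this change only loosely: a six-membered aromatic ring stays in place, and the 1H-pyrrol-2-yl of compound 1 is not restored, so a partial return rather than full recovery is expected. Compound 3 is estimated at 2000 nM (range 200 nM to 10000 nM), an expected step of an at least 5.0-fold lower number from compound 2 to compound 3 (0.69 log units; beyond the scatter).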

Compound 3, inhibition constant: > 10000 nM
Compound 3 was reported as a limit (the forecaster's own chance of this, stated with the estimate: 40%); middle value at least 5.0-fold (0.69 log units) from the limit.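

Replacing 1H-pyrrol-2-yl with 4-(1H-imidazol-1-yl)phenyl gives an at least 1200-fold higher number from compound 1 to compound 3 (3.09 log units; beyond the scatter), so the loss at this position is not particular to 4-chloro-3-(trifluoromethyl)phenyl. Compound 3 gives only a limit in this assay, > 10000 nM, not a number. The step between compound 2 and compound 3 cannot be read, as both values are limits: the limit of > 10000 nM in this assay, at which 2 of the 3 values shown sit.

From the compounds shown here alone, what in 1H-pyrrol-2-yl supports the value of compound 1 stays open. An unsubstituted phenyl or a furan-2-yl on the same carbon would separate ring size from the ring nitrogen.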